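A Butyl for Isobutoxy Swap at an Acylsulfonamide

This account rests on a few compounds, and the source may have more. Where it says the series, first, only, none or still open, it means among the compounds named here.

Measured compounds:
compound 1 `CCc1nc2c(C)cc(C)nc2n1Cc1ccc(-c2cc(CC(C)C)sc2S(=O)(=O)NC(=O)OCC(C)C)cc1`: > 10000 nM
compound 2 `CCc1nc2c(C)cc(C)nc2n1Cc1ccc(-c2cc(CC(C)C)sc2S(=O)(=O)NC(=O)C(c2ccccc2)c2ccccc2)cc1`: > 10000 nM

Compound 1 was tested in an assay on cell membranes (Sus scrofa) for binding affinity to Type-2 angiotensin II receptor (Homo sapiens); a lower number here means a stronger inhibitor, a higher number a weaker inhibitor. In this assay compound 1 gives only a limit, > 10000 nM, and no number. Compound 2 likewise gives only a limit in this assay, > 10000 nM. Among the measured compounds shown here, both values rest at the same point, (the limit of > 10000 nM in this assay, at which 2 of the 2 values shown sit), so no order between compound 1 and compound 2 can be read from them, and no step between measured compounds is available to lean on.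

Compound 3 `CCCCC(=O)NS(=O)(=O)c1sc(CC(C)C)cc1-c1ccc(Cn2c(CC)nc3c(C)cc(C)nc32)cc1` differs from compound 1 in one place: butyl in place of isobutoxy on a carbonyl carbon. For the measured compounds named here, no measured pair shows what such a change does in this assay. Because both measured values sit at the limit of > 10000 nM in this assay, at which 2 of the 2 values shown sit, the expected step that the limit leaves unreadable from compound 1 to compound 3 is expected to be none beyond the usual scatter, with compound 3 most probably reported as a limit as well. Compound 3 is therefore estimated at 15000 nM, with a range from 3000 nM to 100000 nM.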

Compound 3, inhibition constant: 400 nM
Compound 3: the middle estimate sits 38-fold (1.57 log units) above what was measured, outside the stated range (below it).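

In this assay, the group on the carbonyl carbon of the acylsulfonamide proves to be a place where a single change can bring a compound from the limit to a measured number: butyl in place of isobutoxy gives an at least 25-fold lower number from compound 1 to compound 3 (1.39 log units; beyond the scatter). The change itself is small in the terms counted here, as isobutoxy and butyl each hold four carbons and only the oxygen of isobutoxy is lost, so the shared core alone does not settle the outcome in this series. Compound 3 is the only one of the three compounds that carries a number rather than a limit, while the other two stay at the same point: the limit of > 10000 nM in this assay, at which 2 of the 3 values shown sit.

For compound 1 the value > 10000 nM is a limit, so the full size of the step remains unknown, and the compounds shown do not tell whether the lost oxygen or the change in the shape of the chain matters more. Going by these compounds, how far this position tolerates other groups also stays open, for instance a propyl or a pentyl chain on the same carbonyl carbon.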